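Amine variation on the side chain of the shared core

The source may hold more compounds than are shown below. What is called first, only, known or untested is meant among the compounds shown, and "the series" means these compounds.

Measured compounds:
compound 1 `CCNCCCOc1ccc2cc(NC(=O)c3ccc(O)c(CC=C(C)C)c3)c(=O)oc2c1C` — 980 nM
compound 2 `CC(C)=CCc1cc(C(=O)Nc2cc3ccc(OCCCN(C(C)C)C(C)C)c(C)c3oc2=O)ccc1O` — 1310 nM
compound 3 `CC(C)=CCc1cc(C(=O)Nc2cc3ccc(OCCCN(C)C(C)(C)C)c(C)c3oc2=O)ccc1O` — 1140 nM

All three compounds were tested in a functional assay on MCF7 cells (Homo sapiens) for antiproliferative activity; on this read-out lower numbers stand for stronger inhibition and higher numbers for weaker inhibition. Compound 1 stands at the lower end of the three numbers, but its steps to the other two are both inside the scatter: a 1.2-fold higher number from compound 1 to compound 3 (0.07 log units; within the scatter), and a 1.3-fold higher number from compound 1 to compound 2 (0.13 log units; within the scatter). The remaining pair behaves the same way, with a 1.1-fold lower number from compound 2 to compound 3 (0.06 log units; within the scatter). Across these three compounds the substituents on the amine nitrogen of the chain vary widely, yet the read-out does not move beyond the scatter.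

Compound 4 `CC(C)=CCc1cc(C(=O)Nc2cc3ccc(OCCCNCc4ccccc4)c(C)c3oc2=O)ccc1O` has not yet been measured in this assay. Relative to compound 1 the change is phenyl in place of methyl on a saturated chain carbon bound to an amine nitrogen. This is again a change at the amine nitrogen end of the chain, the same region varied in the three measured steps, each of which stayed within the scatter. Going by the values given here, a phenyl is a larger change than those seen so far, and no measured step covers an aromatic ring at this position, so some extra uncertainty remains.

On that basis the expected step of a 1.1-fold higher number from compound 1 to compound 4 (0.05 log units; within the scatter) is small, with no direction beyond the scatter. Compound 4 is estimated at 1100 nM, with a range from 450 nM to 2700 nM.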

Compound 4, half-maximal inhibitory concentration: 910 nM
For compound 4 the middle estimate is 1.2-fold (0.08 log units) above the measured one; low and high end bracket the measured number.
By their numbers in this assay, from the lowest: compounds 4, 1, 3 and 2 (each within the scatter of the next).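

Carrying a six-membered aromatic ring at the amine end of the chain does not shift the read-out in this assay beyond the scatter, with a 1.1-fold lower number from compound 1 to compound 4 (0.03 log units; within the scatter) for the change from ethylamino to benzylamino. The comparisons with the two more branched amines stay inside it as well, with a 1.3-fold lower number from compound 3 to compound 4 (0.10 log units; within the scatter) for benzylamino in place of methyl(tert-butyl)amino and a 1.4-fold lower number from compound 2 to compound 4 (0.16 log units; within the scatter) for benzylamino in place of diisopropylamino, so the four amine groups shown, now including an aromatic one, cannot be told apart in this read-out. No measurement on hand offers an explanation for this flat behaviour at the chain end.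

On these data alone, all four compounds keep a basic-looking amine nitrogen at the end of the same chain on the shared core, so it remains open whether the read-out would hold with a ring amine such as morpholine or piperazine, with a carboxylic acid or a neutral amide in place of the amine, or with a substituted benzylamino group such as fluorobenzylamino. As far as these compounds go, a longer or shorter chain between the ring oxygen and the amine nitrogen is equally open, as is any change away from the chain end.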